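The compounds below may be only part of what the source reports. "The series", "measured", "known", "first", "only" and "open" are said of these compounds alone.

Working notes on the series. Compound 1 `Cc1ccc(NC(=O)C(=O)Nc2ccc(OCC(=O)O)c(F)c2)cc1`, compound 2 `Cc1cccc(NC(=O)C(=O)Nc2ccc(OCC(=O)O)c(F)c2)c1` and compound 3 `O=C(O)COc1ccc(NC(=O)C(=O)Nc2cccc(Cl)c2)cc1F` share one core and differ only in the group carried on an amide-type nitrogen. In a functional assay on CHO cells for agonist activity at Free fatty acid receptor 1 (Homo sapiens), read by FLIPR, tested at 100 nM (on this read-out higher numbers stand for a stronger effect at the one concentration tested and lower numbers for a weaker effect), compound 1 gives 11.4%, compound 2 gives 17.7% and compound 3 gives 13.3%. Compound 3 thus stands second highest of the three numbers in this assay, though within the scatter of both neighbours: a number 1.9 percentage points higher from compound 1 to compound 3 (within the scatter) and a number 4.4 percentage points lower from compound 2 to compound 3 (within the scatter). Compound 4 `COc1ccccc1NC(=O)C(=O)Nc1ccc(OCC(=O)O)c(F)c1` differs from compound 3 by 2-methoxyphenyl in place of 3-chlorophenyl on an amide-type nitrogen. Within the data shown here, the steps that bear on this exchange are a number 6.3 percentage points higher from compound 1 to compound 2 (within the scatter), a number 1.9 percentage points higher from compound 1 to compound 3 (within the scatter) and a number 4.4 percentage points lower from compound 2 to compound 3 (within the scatter), all within the scatter, so no step beyond the scatter is expected in this assay in either direction. Compound 4 is therefore estimated at 14%, between 5% and 26%, meaning an expected step of a number 0.7 percentage points higher from compound 3 to compound 4 (within the scatter).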

Compound 4, a percentage reported as activity, at one concentration (the size of the read-out at that concentration, not a potency): 6.78%
The estimate for compound 4 lay 7.2 percentage points above the measured number; the range from low to high includes it.
By their numbers in this assay, from the lowest: compounds 4, 1, 3 and 2 (each within the scatter of the next, the first and the last beyond it).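

In this assay, the exchange at the amide-type nitrogen now gives a step beyond the scatter, though a modest one, for 2-methoxyphenyl in place of 3-methylphenyl (a number 10.9 percentage points lower from compound 2 to compound 4 (beyond the scatter)). The exchanges for 3-chlorophenyl (a number 6.5 percentage points lower from compound 3 to compound 4 (within the scatter)) and 4-methylphenyl (a number 4.6 percentage points lower from compound 1 to compound 4 (within the scatter)) stay within the scatter, so this position separates only compound 2 and compound 4 so far. No available evidence accounts for that step.

From the compounds shown here alone, whether the step follows the methoxy group or its place on the ring remains open. A 3-methoxyphenyl or an aminophenyl group could stand with either compound.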